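A few compounds are considered here, and "the series" means these few. Any claim that something is new, unique, unknown or untested is made for them only; others in the source may bear on it.

Measured so far:
compound 1, `C#CCC(O)(c1ccc(N2CCN(S(=O)(=O)c3ccc(N)nc3)C[C@@H]2C#CC)cc1)C(F)(F)F`, in an assay on cells (Hepatocyte) for inhibition of glucokinase regulatory protein (Mus musculus), with stated times of 20 min and 40 min (a higher number here means that more compound is needed for the effect, a lower number that less compound is needed), gives 130 nM
compound 2, `CC#C[C@H]1CN(S(=O)(=O)c2ccc(N)nc2)CCN1c1ccc(C(C)=O)cc1`, in this assay gives > 12500 nM

The value for compound 2 is a limit of this assay, not a number; it is the limit of > 12500 nM in this assay, at which 1 of the 2 values shown sits. Compound 2 thus stands at the weak end of what is shown, with no figure of its own. Among the compounds with values here, the one measured step bearing on the series is an at least 96-fold higher number from compound 1 to compound 2 (1.98 log units; beyond the scatter), where the acetyl of compound 2 replaced the larger hydroxylated, trifluoromethyl-bearing group of compound 1.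

Compound 3, `CC#C[C@H]1CN(S(=O)(=O)c2ccc(N)nc2)CCN1c1ccc([C@](O)(CO)C(F)(F)F)cc1`, goes the other way: 1,2-dihydroxy-1-(trifluoromethyl)ethyl in place of acetyl on an aromatic carbon. This returns a hydroxyl and a trifluoromethyl on the same carbon to the aromatic carbon para to a large group, while the propynyl chain of compound 1 is replaced by a hydroxymethyl. Given the large step from compound 1 to compound 2 on removal of that kind of group, a large drop in the number in this assay is expected on its return, though the hydroxymethyl has no measured counterpart and leaves the size uncertain. For compound 3 the expected step is an at least 25-fold lower number from compound 2 to compound 3 (1.39 log units; beyond the scatter). Compound 3 is estimated at 500 nM, with a range from 100 nM to 4000 nM.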

Compound 3, half-maximal effective concentration: 98 nM
Beside the measured number, compound 3's estimate is 5.1-fold (0.71 log units) above it; the measured number lies below the stated range.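

At this position, an aromatic carbon para to a large group, 1,2-dihydroxy-1-(trifluoromethyl)ethyl in place of acetyl gives, in this assay, an at least 120-fold lower number from compound 2 to compound 3 (2.10 log units; beyond the scatter), so recovery of the number does not depend on the propynyl chain of the earlier active group. Compound 2 carries a limit of the assay, not a number: the limit of > 12500 nM in this assay, at which 1 of the 3 values shown sits. Exchange of the propynyl chain for hydroxymethyl, with the hydroxyl and trifluoromethyl kept on the same carbon, gives a 1.3-fold lower number from compound 1 to compound 3 (0.12 log units; within the scatter), so the two groups cannot be told apart in this assay and this part of the substituent tolerates the change in the two forms shown.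

The compounds shown leave open whether the hydroxyl, the trifluoromethyl or the two together account for the difference from acetyl, since both groups appear only together here, and a methyl in place of the trifluoromethyl or an amine in place of the hydroxyl would separate them. Also open, going by these compounds, are the opposite configuration at the defined stereocentre and whether a carboxylic acid or a longer chain in place of the hydroxymethyl would hold the number in the same range.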